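From a Trifluoromethylphenyl Amide to an Oxazole Amide

This account rests on a few compounds, and the source may have more. Where it says the series, first, only, none or still open, it means among the compounds named here.

Two compounds share a core and differ only in the group on the carbonyl carbon of the amide. Compound 1 `CC(C)C(=O)Nc1c(C(O)(C(F)(F)F)C(F)(F)F)ccc2ccccc12` carries an isopropyl there; in an assay on LtK cells with ATP-sensitive inward rectifier potassium channel 11 (Homo sapiens) as the target (a higher number here means that more compound is needed for the effect, a lower number that less compound is needed), compound 1 gives 6630 nM. Compound 2 `O=C(Nc1c(C(O)(C(F)(F)F)C(F)(F)F)ccc2ccccc12)c1ccc(C(F)(F)F)cc1` carries a 4-(trifluoromethyl)phenyl instead, and in this assay compound 2 gives 160 nM. That single change made a large step: a 41-fold lower number from compound 1 to compound 2 (1.62 log units; beyond the scatter). Compound 2 thus stands with the lowest number of the two measured, and compound 1 lies far behind it.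

Compound 3 `O=C(Nc1c(C(O)(C(F)(F)F)C(F)(F)F)ccc2ccccc12)c1cnco1` has not been measured. It differs from compound 2 in one place: 1,3-oxazol-5-yl in place of 4-(trifluoromethyl)phenyl on a carbonyl carbon. Going by the values given here, the only measured step that bears on this position is the one from compound 1 to compound 2, which shows that a six-membered aromatic ring on the carbonyl carbon gives a far lower number than an isopropyl. An oxazol-5-yl is also aromatic, but it is built of fewer atoms and brings hydrogen-bond acceptors; nothing measured tells how such a ring behaves here. The expectation for compound 3 in this assay is therefore a moderately higher number than compound 2, a 5.0-fold higher number from compound 2 to compound 3 (0.70 log units; beyond the scatter), with wide uncertainty. Compound 3 is estimated at 800 nM, between 250 nM and 2500 nM.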

Compound 3, half-maximal effective concentration: 24 nM
Compound 3: the middle estimate sits 33-fold (1.52 log units) above what was measured; measured number outside the range, below it.
By their numbers in this assay, from the lowest: compound 3; then compound 2; then compound 1.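

In this assay the group on this carbonyl carbon does not have to be a six-membered ring of carbon only: with the 1,3-oxazol-5-yl, which has 5 heavy atoms, fewer than the 4-(trifluoromethyl)phenyl, and 2 hydrogen-bond acceptors against 0, the result is a 6.7-fold lower number from compound 2 to compound 3 (0.82 log units; beyond the scatter), a further drop beyond the one seen earlier. Measured against the isopropyl, the new ring gives a 280-fold lower number from compound 1 to compound 3 (2.44 log units; beyond the scatter), so among these three groups the larger aromatic group does not give the lowest number, and the five-membered ring with 2 hetero atoms now leads the set. Nothing measured here gives a reason for this drop.

From the compounds shown here alone, whether the gain comes from the ring nitrogen, the ring oxygen or simply the smaller ring stays open, and a furan-2-yl or a thiazol-5-yl on the same carbonyl carbon would help to separate these, while a plain phenyl would show what the trifluoromethyl contributes in compound 2. Also open, going by these compounds, is how the number responds when the oxazole itself carries an extra group, such as a methyl.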